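Ring-closed amine on the core of compound 1

This account rests on a few compounds, and the source may have more. Where it says the series, first, only, none or still open, it means among the compounds named here.

The three compounds measured here share one core, and compound 1 `COc1cccc(-c2c(C)n(Cc3c(F)cccc3F)c(=O)n([C@@H](C)CNCc3ccccc3)c2=O)c1` stands at the top of the numbers: in an assay on HEK293 cells for binding affinity to Gonadotropin-releasing hormone receptor (Homo sapiens) (a lower number here means a stronger inhibitor, a higher number a weaker inhibitor), compound 1 gives 370 nM. Compound 2 `COc1cccc(-c2c(C)n(Cc3c(F)cccc3F)c(=O)n([C@H](C)CNCc3ccccc3)c2=O)c1` is its mirror form at the chain stereocentre and gives 75 nM, a step of a 4.9-fold lower number from compound 1 to compound 2 (0.69 log units; beyond the scatter), which rests on (the fact that compounds 1 and 2 differ only in the configuration as drawn). Compound 3 `COc1cccc(-c2c(C)n(Cc3c(F)cccc3F)c(=O)n([C@H](C)CNCc3cccc(F)c3)c2=O)c1` gives 85 nM; from compound 1 the change is a 4.4-fold lower number from compound 1 to compound 3 (0.64 log units; beyond the scatter), while the added fluoro alone shows a 1.1-fold higher number from compound 2 to compound 3 (0.05 log units; within the scatter).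

Compound 4 `COc1cccc(-c2c(C)n(Cc3c(F)cccc3F)c(=O)n(C3CCN(Cc4ccccc4)C3)c2=O)c1` is the next step from compound 1: 1-benzylpyrrolidin-3-yl in place of 1-((benzylamino)methyl)ethyl on an aromatic nitrogen.

Of the measured steps, the configuration step bears most on this change, since compound 4 has no defined stereocentre on the group that enters, and the fluoro step tells that small edits on the benzyl ring hardly move the number. The configuration step was modest but beyond the scatter; the fluoro step was within it. A modest step downward from compound 1 is therefore expected, short of what compound 2 reached, as a 1.9-fold lower number from compound 1 to compound 4 (0.27 log units; within the scatter). Compound 4 is thus estimated at 200 nM, with a range from 60 nM to 700 nM.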

Compound 4, inhibition constant: 280 nM
Compound 4: middle estimate off by 1.4-fold (0.15 log units), on the low side, and the stated range covers the measured number.
By their numbers in this assay, from the lowest: compounds 2 and 3 (each within the scatter of the next); then compounds 4 and 1 (each within the scatter of the next).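

In this assay, the 1-benzylpyrrolidin-3-yl group on this aromatic nitrogen holds the number of the open chain, with a 1.3-fold lower number from compound 1 to compound 4 (0.12 log units; within the scatter), although it enters with 0 hydrogen-bond donors where the chain had 1, so in this pair the donor of the chain is not needed to keep that number. The ring does not match the other two chain compounds, with a 3.7-fold higher number from compound 2 to compound 4 (0.57 log units; beyond the scatter) and a 3.3-fold higher number from compound 3 to compound 4 (0.52 log units; beyond the scatter). How the ring compares with the chain thus depends on which chain configuration is taken, and compound 4 has no defined stereocentre on this group, whereas the gap between the chain forms stands on configuration alone: the fact that compounds 1 and 2 differ only in the configuration as drawn.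

The compounds shown leave open whether the two configurations of the 1-benzylpyrrolidin-3-yl group would separate as compounds 1 and 2 do, and whether a 3-fluorobenzyl group on the pyrrolidine nitrogen would leave the number as unchanged as the fluoro did on the chain. They also leave open how the number responds to ring size, which a 1-benzylpiperidin-3-yl group at the same place would test.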